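This account rests on a few compounds, and the source may have more. Where it says the series, first, only, none or still open, it means among the compounds named here.

Compound 1 `O=C1C(Nc2ccc(Br)cc2)=CC(=O)c2c1nc1n2[C@H]2OC[C@@H](O)[C@H]2OC1` gives 5220 nM in a functional assay on HeLa cells (Homo sapiens) for inhibition, read by sulforhodamine B assay (on this read-out higher numbers stand for weaker inhibition and lower numbers for stronger inhibition), the higher of the two numbers reported, though compound 2 `O=C1C=C(Nc2ccc(Br)cc2)C(=O)c2c1nc1n2[C@H]2OC[C@@H](O)[C@H]2OC1`, which gives 3830 nM in this assay, sits within the scatter of it, so no order between these two can be claimed. Compound 3 `CCCN(CCC)C1=CC(=O)c2nc3n(c2C1=O)[C@H]1OC[C@@H](O)[C@H]1OC3` reaches only a limit of the assay, > 16000 nM, and not a number. Among the measured compounds shown here, the same change that turned compound 2 into compound 3 is now applied to compound 1 to give compound 4 `CCCN(CCC)C1=CC(=O)c2c(nc3n2[C@H]2OC[C@@H](O)[C@H]2OC3)C1=O`: dipropylamino in place of (4-bromophenyl)amino on a double-bonded ring carbon Only one measured step bears on this, an at least 4.1-fold higher number from compound 2 to compound 3 (0.62 log units; beyond the scatter). Because an at least 4.1-fold higher number from compound 2 to compound 3 (0.62 log units; beyond the scatter) was at least modest, compound 4 is expected to read higher as well, a 4.8-fold higher number from compound 1 to compound 4 (0.68 log units; beyond the scatter), quite possibly only as a limit. Compound 4 is therefore estimated at 25000 nM, in the range 10000 nM to 80000 nM.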

Compound 4, half-maximal inhibitory concentration: > 16000 nM
Compound 4 ended at the assay's limit (the forecaster's own chance of this, stated with the estimate: 70%); the middle value lies beyond the limit too.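

On the core of compound 1, too, the change weakens inhibition in this assay: dipropylamino in place of (4-bromophenyl)amino gives an at least 3.0-fold higher number from compound 1 to compound 4 (0.48 log units; beyond the scatter). The direction of the step therefore no longer rests on a single core, but its size cannot be compared: the same change on two cores in this assay, an at least 4.1-fold higher number (0.62 log units; beyond the scatter) from compound 2 to compound 3 and an at least 3.0-fold higher number (0.48 log units; beyond the scatter) from compound 1 to compound 4; the limit leaves it open whether they differ. Both dipropylamino compounds give only a limit, not a number: the limit of > 16000 nM in this assay, at which 2 of the 4 values shown sit.

From the compounds shown here alone, how far compound 3 and compound 4 lie past that limit remains open, so no order between them can be told. Also open, going by these compounds, is how propylamino or unsubstituted phenylamino would read at this position.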